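The compounds below may be only part of what the source reports. "The series", "measured", "known", "first", "only" and "open" are said of these compounds alone.

The measured compounds:
Compound 1, `COc1cc(C)cc(-c2nn(CC#N)cc2-c2ccc(-c3cccc(C(C)=O)c3)nc2)c1`, with 83%
Compound 2, `Cc1cc(O)cc(-c2nn(CC#N)cc2-c2ccnc(-c3ccc(Oc4ccccc4)cc3)c2)c1`, with 108%
Compound 3, `COc1cc(C)cc(-c2nn(CC#N)cc2-c2ccnc(-c3ccc(N(C)C)cc3)c2)c1`, with 99%

All three were tested in a functional assay on HOP-62 cells (Homo sapiens) for cytotoxicity, read by sulforhodamine B assay, with a stated time of 48 h, tested at 0.01 uM; a higher number here means a weaker effect of the compound at the concentration tested, a lower number a stronger effect. Compound 3 gives 99% there, the second highest of the three numbers. Its nearest neighbour is compound 2, whose 108% is higher by an amount that lies within the usual scatter, so the two cannot be told apart. The furthest is compound 1, whose 83% is lower by an amount that lies beyond the scatter. No pair among these three differs in only one place, so no single-point step is available from them.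

Compound 4, `Cc1cc(O)cc(-c2nn(CC#N)cc2-c2ccnc(-c3ccc(N(C)C)cc3)c2)c1`, has not yet been measured. It differs from compound 3 in one place: hydrogen in place of methyl on an oxygen on an aromatic ring. Compound 2 also carries a hydroxy group on that ring, and its value and that of compound 3 fall within the scatter of each other, though compound 2 differs from compound 3 elsewhere as well. On this thin basis the step expected in this assay is a number 1 percentage points higher from compound 3 to compound 4 (within the scatter), which is to say none beyond the scatter. Compound 4 is therefore estimated at 100%, with a range from 85% to 115%.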

Compound 4, a percentage reported as activity, at one concentration (the size of the read-out at that concentration, not a potency): 89%
For compound 4 the middle estimate is 11 percentage points above the measured one, and the stated range covers the measured number.
By their numbers in this assay, from the lowest: compounds 1, 4, 3 and 2 (each within the scatter of the next, the first and the last beyond it).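

Going from methoxy to hydroxy on the 3-methoxy-5-methylphenyl ring gives the first step at this position that changes only one place, and with dimethylamino held constant it amounts to a number 10 percentage points lower from compound 3 to compound 4 (within the scatter) in this assay; at this position, then, hydrogen and methyl on the oxygen on the aromatic ring cannot be told apart in this read-out. With the hydroxy group held constant, dimethylamino in place of phenoxy on an aromatic carbon gives a number 19 percentage points lower from compound 2 to compound 4 (beyond the scatter) and so, unlike the change on the oxygen, this one is a modest shift that can be read. These two steps rest on a single pair each, and no measurement that could explain either of them is available.

Going by these compounds, whether a longer chain such as ethyl on that oxygen, or an amine such as piperidine in place of dimethylamino on the aromatic carbon, would move the number further remains open. The read-out comes from one concentration, so it shows only the size of the effect at that concentration; it leaves open whether these compounds would show a stronger or weaker effect at other concentrations, and whether the methoxy-to-hydroxy change would stay this small alongside phenoxy.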